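The source may hold more compounds than are shown below. What is called first, only, known or untested is meant among the compounds shown, and "the series" means these compounds.

In a functional assay on the whole organism (plasma) with Rattus norvegicus as the target (on this read-out higher numbers stand for an effect only at larger amounts of compound and lower numbers for an effect already at smaller amounts), compound 1 `O=C(Nc1c(F)cc(F)cc1F)N(Cc1cccc(-c2cc[nH]n2)c1)C1CCCCCC1` gives 0.79 mg/kg and so stands within the scatter of compound 3 `CSc1cc(C)nc(SC)c1NC(=O)N(Cc1ccccc1)Cc1cccc(-c2cc[nH]n2)c1` at 0.44 mg/kg and well under compound 2 `O=C(Nc1c(F)cc(F)cc1F)N(Cc1ccccc1)Cc1cccc(-c2cc[nH]n2)c1` at 8.6 mg/kg on this read-out. Compound 4 `Cc1cc(C)c(NC(=O)N(Cc2cccc(-c3cc[nH]n3)c2)C2CCCCCC2)c(C)c1` differs from compound 1 by 2,4,6-trimethylphenyl in place of 2,4,6-trifluorophenyl on an amide-type nitrogen with 2,4,6-trimethylphenyl in place of 2,4,6-trifluorophenyl on an amide-type nitrogen. The closest measured change is a 20-fold lower number from compound 2 to compound 3 (1.29 log units; beyond the scatter) which was large and also removed 2,4,6-trifluorophenyl from that nitrogen. The other step, an 11-fold higher number from compound 1 to compound 2 (1.04 log units; beyond the scatter) with benzyl in place of cycloheptyl, concerns a different group. No measurement covers 2,4,6-trimethylphenyl itself, so only a smaller shift in the same direction is expected in this assay here. The estimated change is a 2.6-fold lower number from compound 1 to compound 4 (0.42 log units; beyond the scatter) and remains uncertain. For compound 4 the expected value is 0.3 mg/kg with an estimated range of 0.08 mg/kg to 1.2 mg/kg as its span.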

Compound 4, dose for half-maximal effect: 2 mg/kg
Estimate against measurement, compound 4: 6.7-fold (0.82 log units) below; the whole stated range lies below it.
By their numbers in this assay, from the lowest: compounds 3 and 1 (each within the scatter of the next); then compound 4; then compound 2.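

In this assay, 2,4,6-trimethylphenyl in place of 2,4,6-trifluorophenyl on the amide-type nitrogen, with cycloheptyl kept, gives a 2.5-fold higher number from compound 1 to compound 4 (0.40 log units; beyond the scatter). This step runs opposite in direction to the earlier change on that nitrogen, a 20-fold lower number from compound 2 to compound 3 (1.29 log units; beyond the scatter), which brought in a different group on a benzyl-bearing compound. No measured evidence accounts for the step from trifluorophenyl to trimethylphenyl. From the compounds shown here alone, whether this replacement would act the same way with benzyl in place of cycloheptyl remains open, as does the effect of a chlorine-bearing or methoxy-bearing phenyl ring on this nitrogen.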